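This account rests on a few compounds, and the source may have more. Where it says the series, first, only, none or still open, it means among the compounds named here.

Two compounds share one core. Compound 1 `CN(C(=O)NC(=O)c1cccc([N+](=O)[O-])c1)c1nc(C(F)(F)F)c(C(=O)N/N=C/c2ccccc2C(F)(F)F)s1` carries a 3-nitrophenyl group on a carbonyl carbon, and compound 2 `CN(C(=O)NC(=O)c1c(Cl)cccc1Cl)c1nc(C(F)(F)F)c(C(=O)N/N=C/c2ccccc2C(F)(F)F)s1` carries a 2,6-dichlorophenyl group in that place. In a functional assay on HepG2 cells (Homo sapiens) for inhibition, read by MTT assay, with a stated time of 72 h (on this read-out lower numbers stand for stronger inhibition and higher numbers for weaker inhibition), compound 1 gives 4.8 ug/mL, and in this assay compound 2 gives 8.95 ug/mL. Going by the values given here, the single measured step is a 1.9-fold higher number from compound 1 to compound 2 (0.27 log units; within the scatter); compound 2 thus holds the higher of the two numbers, but that gap is within the scatter, so the two compounds are not separated by this read-out.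

Compound 3 `CN(C(=O)NC(=O)c1ccc(Cl)cc1Cl)c1nc(C(F)(F)F)c(C(=O)N/N=C/c2ccccc2C(F)(F)F)s1` has not yet been measured. It differs from compound 2 in one place: 2,4-dichlorophenyl in place of 2,6-dichlorophenyl on a carbonyl carbon. Among the compounds with values here, no measured step compares one dichlorophenyl group with another. Within the data shown here, the only step available exchanges a whole group on that same carbonyl carbon, a 1.9-fold higher number from compound 1 to compound 2 (0.27 log units; within the scatter), and even that exchange stayed within the scatter. There is therefore no ground for expecting a step beyond the scatter in this assay in either direction. The estimate for compound 3 is 8 ug/mL, with a range from 4 ug/mL to 16 ug/mL, which corresponds to an expected step of a 1.1-fold lower number from compound 2 to compound 3 (0.05 log units; within the scatter).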

Compound 3, half-maximal inhibitory concentration: 10.7 ug/mL
The estimate for compound 3 lay 1.3-fold (0.13 log units) below the measured number, within the range that was stated.
By their numbers in this assay, from the lowest: compounds 1, 2 and 3 (each within the scatter of the next, the first and the last beyond it).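

Moving one chlorine, with 2,4-dichlorophenyl in place of 2,6-dichlorophenyl on the carbonyl carbon, gives the first direct comparison of two dichlorophenyl groups: in this assay, the result is a 1.2-fold higher number from compound 2 to compound 3 (0.08 log units; within the scatter) and the read-out does not separate these two arrangements of the same atoms. Going by these compounds alone, the exchange of 3-nitrophenyl for 2,4-dichlorophenyl gives a 2.2-fold higher number from compound 1 to compound 3 (0.35 log units; beyond the scatter) and is the first step at this position to pass the scatter, though it is modest and compound 2 remains within the scatter of both compound 1 and compound 3, so the dichlorophenyl compounds do not form a group clearly apart from compound 1. No measurement is available that explains either step.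

The compounds shown leave open how this position would respond to a phenyl ring carrying a single chlorine, or to a group with no aromatic ring, such as cyclohexyl or a short alkyl chain. They also leave open whether the modest gap between compound 1 and compound 3 would hold up outside this assay in another kind of test.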